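The source may report more compounds than this note shows. Statements on the series, on what has been measured and on what is new or still open speak of the compounds shown alone.

Compound 1 `O=c1cc(Cn2cc(CCCCl)nn2)c2ccc(O)cc2o1` is the starting point. In a functional assay on A549 cells (Homo sapiens) for inhibition, read by MTT assay, with a stated time of 72 h (a higher number here means a weaker inhibitor, a lower number a stronger inhibitor), compound 1 gives 30100 nM, the lowest of the two numbers available. Compound 2 `O=c1cc(Cn2cc(CCO)nn2)c2ccc(O)cc2o1` gives 90300 nM in this assay. Compound 3 `O=c1cc(Cn2cc(CCCCO)nn2)c2ccc(O)cc2o1` reaches only the limit of this assay, > 100000 nM, so for it there is a limit and not a number. The step of a 3.0-fold higher number from compound 1 to compound 2 (0.48 log units; beyond the scatter) and the step of an at least 3.3-fold higher number from compound 1 to compound 3 (0.52 log units; beyond the scatter) both weaken inhibition modestly, and each adds a hydroxy group to the side chain. Compound 4 `CC(C)(C)c1cn(Cc2cc(=O)oc3cc(O)ccc23)nn1` differs from compound 1 in one place: tert-butyl in place of 3-chloropropyl on an aromatic carbon. Neither measured step removes the chlorine while leaving the chain free of a hydroxy group, so neither matches the present change closely; what both show is that reshaping the end of this chain moves the number by a modest amount. The expected step is therefore small, a 1.3-fold higher number from compound 1 to compound 4 (0.12 log units; within the scatter), with a weaker inhibitor somewhat more likely than a stronger one. Compound 4 is expected to give about 40000 nM in this assay, most likely between 12000 nM and 100000 nM.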

Compound 4, half-maximal inhibitory concentration: 67600 nM
The estimate for compound 4 lay 1.7-fold (0.23 log units) below the measured number; the range from low to high includes it.
By their numbers in this assay, from the lowest: compound 1; then compounds 4 and 2 (each within the scatter of the next). At a limit, above all of these: compound 3.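

Replacing 3-chloropropyl with tert-butyl brings in no hydroxy group, yet it still gives a 2.2-fold higher number from compound 1 to compound 4 (0.35 log units; beyond the scatter), so at this aromatic carbon inhibition can weaken without a hydroxy group entering. Between the two other groups, the step is a 1.3-fold lower number from compound 2 to compound 4 (0.13 log units; within the scatter), so tert-butyl and 2-hydroxyethyl cannot be told apart in this assay. Compound 3 stands at a limit and not at a number, and an at least 1.4-fold lower number from compound 3 to compound 4 (0.17 log units; that floor lies within the scatter) gives only a floor: the limit of > 100000 nM in this assay, at which 1 of the 4 values shown sits.

From the compounds shown here alone, whether the edge of compound 1 belongs to its chlorine or to its unbranched chain remains open, and a plain propyl group in the same place would separate the two. An amine at the end of the chain would show whether other end groups on this chain move the number further.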